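This account rests on a few compounds, and the source may have more. Where it says the series, first, only, none or still open, it means among the compounds named here.

Measured so far:
compound 1 `CNc1nc(Nc2ccc(C)c([N+](=O)[O-])c2)ncc1C(=O)Nc1cc(NC(=O)c2cccc(C(F)(F)F)c2)ccc1C`: > 10000 nM
compound 2 `Cc1ccc(NC(=O)c2cccc(C(F)(F)F)c2)cc1NC(=O)c1cnc(Nc2ccc(C)c([N+](=O)[O-])c2)nc1N(C)C`: > 10000 nM

In an ADME assay on BaF3 cells (Mus musculus) for antiproliferative activity, read by CellTiter-Glo and CCK-8 assay, with a stated time of 72 h (a lower number here means a stronger inhibitor of growth, a higher number a weaker inhibitor of growth), compound 1 gives > 10000 nM, which is a limit of the assay and not a number. In this assay compound 2 gives > 10000 nM, likewise a limit. Among the compounds with values here, the single measured step, a step that the two limits leave unreadable from compound 1 to compound 2, is therefore unreadable in size. Compound 2 stands at the limit of > 10000 nM in this assay, at which 2 of the 2 values shown sit, and nothing on the numbers separates it from compound 1.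

Compound 3 `Cc1ccc(NC(=O)c2cccc(C(F)(F)F)c2)cc1NC(=O)c1cnc(Nc2ccc(C)c([N+](=O)[O-])c2)nc1` differs from compound 2 by hydrogen in place of dimethylamino on an aromatic carbon. Within the data shown here, no measured step touches this position, and the one recorded step gives no readable size, so there is no basis for expecting a shift in this assay in either direction; the step from compound 2 to compound 3 is expected to be a number no higher from compound 2 to compound 3 (the limit leaves the size open), with compound 3 most likely again reported only as a limit. Compound 3 is estimated at 10000 nM in this assay, within 2000 nM to 30000 nM.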

Compound 3, concentration for 50% growth inhibition: 8700 nM
For compound 3 the middle estimate is 1.1-fold (0.06 log units) above the measured one; measured number inside the range.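

Within the data shown here, with hydrogen on this aromatic carbon, compound 3 gives the first number of the series in this assay rather than a limit. Against dimethylamino, the change has only a floor (an at least 1.1-fold lower number from compound 2 to compound 3 (0.06 log units; that floor lies within the scatter)), and the same holds against methylamino (an at least 1.1-fold lower number from compound 1 to compound 3 (0.06 log units; that floor lies within the scatter)). Neither floor goes beyond the scatter, so compound 3 is not shown to differ from the two compounds carrying an amino group here.

As far as these compounds go, whether methoxy, chlorine or a longer chain such as ethylamino on this carbon would move the number remains open, and the step between methylamino and dimethylamino cannot be read. The true size of both steps to compound 3 also stays open: the limit of > 10000 nM in this assay, at which 2 of the 3 values shown sit.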